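The source may report more compounds than this note shows. Statements on the series, on what has been measured and on what is new or still open speak of the compounds shown alone.

Measured compounds:
compound 1, `CCc1cc2c(cc1C(=O)c1ccc(C(=O)O)cc1)C(C)(C)CCC2(C)C`: in an assay on CV-1 cells with retinoic acid receptor beta (Homo sapiens) as the target (on this read-out lower numbers stand for an effect already at smaller amounts and higher numbers for an effect only at larger amounts of compound), compound 1 gives > 10000 nM, a limit of the assay and not a number.
compound 2, `C=C(c1ccc(C(=O)O)cc1)c1cc2c(cc1C(C)C)C(C)(C)CCC2(C)C`: in this assay compound 2 gives > 10000 nM, likewise a limit and not a number.

Compound 2 therefore stands at the limit of > 10000 nM in this assay, at which 2 of the 2 values shown sit. Going by the values given here, neither value shown is a number, so no ordering between compound 1 and compound 2 can be read from them, and no step between measured compounds is available for this series.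

Compound 3, `C=C(c1ccc(C(=O)O)cc1)c1cc2c(cc1Br)C(C)(C)CCC2(C)C`, is not yet measured in this assay. It differs from compound 2 by bromo in place of isopropyl on an aromatic carbon. Among the compounds with values here, no measured step covers this kind of change. No shift beyond the usual scatter is expected in either direction, and the most likely outcome for compound 3 is again a limit rather than a number. The step implied by this estimate, a step that the limit leaves unreadable from compound 2 to compound 3, is expected to lie within the scatter. Compound 3 is estimated at 15000 nM, with a range from 3000 nM to 50000 nM.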

Compound 3, half-maximal effective concentration: > 10000 nM
Compound 3 gave a limit, no number; the forecaster's own chance of this, stated with the estimate: 70%; the middle value is on the limit's open side.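

In this assay compound 3 gives > 10000 nM, a limit of the assay and not a number. Going by these compounds alone, compound 2 also sits at a limit, so no step from compound 2 to compound 3 can be read. The compounds shown leave open what effect bromo in place of isopropyl has on this read-out, and whether any of them gives a number: the limit of > 10000 nM in this assay, at which 3 of the 3 values shown sit.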